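From Compound 3 to Compound 4: a Halogen Exchange

The compounds below may be only part of what the source reports. "The series", "measured", "known", "first", "only" and "open" are said of these compounds alone.

Three compounds built on one shared core have so far been characterised in a functional assay on CHO cells for positive allosteric modulation of muscarinic acetylcholine receptor M5 (Homo sapiens), read by calcium flux; a higher number here means a larger maximal response, a lower number a smaller maximal response. Compound 1 `CCN(Cc1ccccc1)C(=O)C1CCN(S(=O)(=O)c2ccc(OC)cc2)CC1` gives 84% in this assay, and compound 2 `CCN(C(=O)C1CCN(S(=O)(=O)c2ccc3occc3c2)CC1)[C@H](C)c1ccccc1` gives 80%. Compound 3 `CCN(Cc1ccc(F)cc1)C(=O)C1CCN(S(=O)(=O)c2ccc3cn[nH]c3c2)CC1` gives 55% and stands lowest of the three: its nearest neighbour is compound 2, and its furthest is compound 1, and both of those gaps lie beyond the usual scatter of repeated measurements, so compound 3 sits clearly under the other two.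

Compound 4 `CCN(Cc1cccc(Cl)c1)C(=O)C1CCN(S(=O)(=O)c2ccc3cn[nH]c3c2)CC1` differs from compound 3 in a single place, (3-chlorophenyl in place of 4-fluorophenyl on a saturated chain carbon bound to an amide-type nitrogen). For the measured compounds named here, no pair among the measured compounds differs by this same exchange, and the three measured compounds differ from one another in several places at once, so no measured step isolates what this change does. Going by the values given here, the only anchor is the value of compound 3 itself.

On that basis the step from compound 3 to compound 4 is expected to be modest, a number 5 percentage points higher from compound 3 to compound 4 (within the scatter), and may well fall within the scatter of this assay. Compound 4 is estimated at 60%, with a range from 40% to 80%.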

Compound 4, largest response reached (reported as percent of maximum), in percent of the reference or control that the assay uses: 77%
Compound 4: middle estimate off by 17 percentage points, on the low side; measured number inside the range.
By their numbers in this assay, from the lowest: compound 3; then compounds 4, 2 and 1 (each within the scatter of the next).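

In this assay, for the compounds shown here, the change to 3-chlorophenyl in place of 4-fluorophenyl on a saturated chain carbon bound to an amide-type nitrogen gives a number 22 percentage points higher from compound 3 to compound 4 (beyond the scatter), and this is the first step that isolates a single place. It shows that the maximal response can shift with the benzyl substituent alone, with the rest of the molecule held constant. The two groups match in heavy-atom count, each with one six-membered aromatic ring of carbon only and no hydrogen-bond donors or acceptors, and no measurement here accounts for the difference between them.

The exchange alters both the halogen and its place on the ring, and this single step cannot tell which of the two carries the change, nor whether a methoxy group, a nitrile or a pyridine ring in place of the phenyl ring would move the response in the same way. Going by these compounds alone, it also remains open whether the same exchange would give a similar step with the other sulfonyl groups, such as the one in compound 1.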